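A few compounds are considered here, and "the series" means these few. Any claim that something is new, unique, unknown or untested is made for them only; others in the source may bear on it.

Measured so far:
Compound 1, `CN(C)C/C=C(/c1ccc(Cl)cc1)c1cccnc1`, in a functional assay on brain for inhibition of Norepinephrine transporter (Rattus norvegicus) (a lower number here means a stronger inhibitor, a higher number a weaker inhibitor), gives 10000 nM.
Compound 2, `CN(C)C/C=C(/c1ccc(C(F)(F)F)cc1)c1cccnc1`, in this assay gives 13000 nM.

Among the compounds with values here, compound 2 and compound 1 are the only two numbers in hand, and they sit within the scatter of each other: the step of a 1.3-fold higher number from compound 1 to compound 2 (0.11 log units; within the scatter) is too small to read as a difference. Neither of the two can be called the stronger inhibitor.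

The next compound, compound 3, `COc1ccc(/C(=C/CN(C)C)c2cccnc2)cc1`, differs from compound 2 in one place: methoxy in place of trifluoromethyl on an aromatic carbon. Within the data shown here, the only measured step that bears on a change at this position is a 1.3-fold higher number from compound 1 to compound 2 (0.11 log units; within the scatter), which exchanged one group for another at the same aromatic carbon and moved the number by no more than the scatter. Among the measured compounds shown here, nothing in hand tells how a methoxy group behaves there; the one precedent for varying this position is flat.

Compound 3 is therefore expected to stay near compound 2, with a step of a 1.3-fold lower number from compound 2 to compound 3 (0.11 log units; within the scatter) that is not expected to exceed the scatter. The estimate for compound 3 in this assay is 10000 nM, with a range from 3000 nM to 32000 nM.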

Compound 3, half-maximal inhibitory concentration: > 28000 nM
Compound 3: a limit, no number; the forecaster's own chance of this, stated with the estimate: 25%; middle value at least 2.8-fold (0.44 log units) from the limit.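

In this assay, the aromatic carbon para to a large group no longer looks indifferent to what it carries: the exchange of chloro for trifluoromethyl gave a 1.3-fold higher number from compound 1 to compound 2 (0.11 log units; within the scatter), whereas methoxy gives an at least 2.1-fold higher number from compound 2 to compound 3 (0.33 log units; beyond the scatter) and an at least 2.8-fold higher number from compound 1 to compound 3 (0.44 log units; beyond the scatter). Within the data shown here, the identity of the group at this carbon therefore matters in this small set, and methoxy, the only one of the three groups compared here with a hydrogen-bond acceptor, is the one that moves the number upward beyond the scatter. Compound 3 stands as a limit of the assay and not as a number, so both of its steps are lower bounds and its true distance from the other two stays undefined: the limit of > 28000 nM in this assay, at which 1 of the 3 values shown sits.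

Open, on these data alone, is whether the upward shift belongs to methoxy alone or extends to other groups on this carbon, such as hydroxyl, an amine or a longer chain like ethoxy. Also open is whether any group at this position gives a lower number than compound 1 and compound 2, which the three compounds shown do not address.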